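The compounds below may be only part of what the source reports. "The series", "measured", "known", "first", "only" and "open" are said of these compounds alone.

Measured so far in a functional assay on HepG2 cells (Homo sapiens) for cytotoxicity, read by MTT assay, with a stated time of 72 h; on this read-out higher numbers stand for weaker inhibition and lower numbers for stronger inhibition:
compound 1 `Cc1cccc2c1cnn2-c1ccc(NC(=O)Nc2ccc(Cl)c(C(F)(F)F)c2)cc1` gives 4000 nM;
compound 2 `CNc1cccc2c1cnn2-c1ccc(NC(=O)Nc2ccc(Cl)c(C(F)(F)F)c2)cc1` gives 3000 nM;
compound 3 `COc1cccc2c1cnn2-c1ccc(NC(=O)Nc2ccc(Cl)c(C(F)(F)F)c2)cc1` gives 4000 nM.

Compound 1 stands level with compound 3 at the digits shown, and together they hold the highest of the three numbers; the step of a 1.3-fold lower number from compound 1 to compound 2 (0.12 log units; within the scatter) is within the scatter, as is no change at the digits printed from compound 1 to compound 3 (within the scatter) and a 1.3-fold higher number from compound 2 to compound 3 (0.12 log units; within the scatter). Across these three compounds, swapping the group on the six-membered carbon ring of the indazole moves this assay by nothing that can be told from noise.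

Compound 4 `O=C(Nc1ccc(-n2ncc3cccnc32)cc1)Nc1ccc(Cl)c(C(F)(F)F)c1` carries a different kind of change: a group of 9 heavy atoms (6 carbon, 3 nitrogen; one five-membered aromatic ring with 2 hetero atoms, one six-membered aromatic ring with 1 hetero atom) in place of a group of 10 heavy atoms (8 carbon, 2 nitrogen; one five-membered aromatic ring with 2 hetero atoms, one six-membered aromatic ring of carbon only), on an aromatic carbon. None of the three measured steps makes this change; they exchange a small substituent on the indazole, whereas here the fused ring itself gains a nitrogen and loses its methyl. The measured steps therefore bear only indirectly, by showing that this end of the molecule tolerates alteration without a shift beyond the scatter. On that basis compound 4 is expected to sit close to compound 1, with the step of no change at the digits printed from compound 1 to compound 4 (within the scatter) expected to lie within the scatter. Within the data shown here, compound 4 is estimated at 4000 nM, within 1500 nM to 11000 nM, the range widened to reflect that no measured step tests a ring change of this kind.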

Compound 4, half-maximal inhibitory concentration: > 32000 nM
Compound 4 ended at the assay's limit; the forecaster's own chance of this, stated with the estimate: 10%; at least 8.0-fold (0.90 log units) between middle value and limit.
By their numbers in this assay, from the lowest: compounds 2, 1 and 3 (each within the scatter of the next). At a limit, above all of these: compound 4.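

The step in this assay is an at least 8.0-fold higher number from compound 1 to compound 4 (0.90 log units; beyond the scatter), the only step shown that lies beyond the scatter. Among these compounds, exchanging the small substituent left the number within the scatter across compounds 1, 2 and 3, whereas replacing the 4-methyl-1H-indazol-1-yl group with a group carrying a hetero atom in its six-membered ring, on the aromatic carbon para to a large group, does move it, so this end of the molecule is less tolerant of a change to the ring than the earlier compounds suggested. Compound 4 gives > 32000 nM, which is a limit of the assay and not a number: the limit of > 32000 nM in this assay, at which 1 of the 4 values shown sits.

The step joins two changes, the added ring nitrogen and the lost methyl, and the compounds shown do not separate them. Also open, as far as these compounds go, is how a methyl, an amine or a carboxylic acid on the nitrogen-bearing ring would read in this assay.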